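Removing one chlorine from compound 2

The source may report more compounds than this note shows. Statements on the series, on what has been measured and on what is new or still open speak of the compounds shown alone.

Compound 1 `Cc1cc(Cl)ccc1NCC(=O)N[C@H]1CCOC1=O` gives > 64000 nM in a functional assay on PC-3 cells (Homo sapiens) for antiproliferative activity, read by MTT assay, with a stated time of 72 h (a higher number here means a weaker inhibitor, a lower number a stronger inhibitor), which is a limit rather than a number.
Compound 2 `O=C(CNc1ccc(Cl)cc1Cl)N[C@H]1CCOC1=O` gives > 64000 nM in this assay, again a limit and not a number.
Compound 3 `O=C(COc1ccc(C(=O)/C=C/c2ccccc2Br)cc1)N[C@H]1CCOC1=O` gives 3260 nM in this assay.

Compound 2 therefore stands at the limit, with no number of its own. Compound 4 `O=C(CNc1ccccc1Cl)N[C@H]1CCOC1=O` differs from compound 2 by hydrogen in place of chloro on an aromatic carbon. Within the data shown here, the only measured step between neighbours, a step that the two limits leave unreadable from compound 1 to compound 2, cannot be read, because both ends rest at the limit of > 64000 nM in this assay, at which 2 of the 3 values shown sit. Among the measured compounds shown here, no measured step thus sizes the change from compound 2 to compound 4, and the expectation is that a number no higher from compound 2 to compound 4 (the limit leaves the size open) shows nothing beyond the scatter. Compound 4 is estimated at 64000 nM (20000 nM to 200000 nM), most likely reported as a limit once more.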

Compound 4, half-maximal inhibitory concentration: > 64000 nM
Compound 4 ended at the assay's limit; the forecaster's own chance of this, stated with the estimate: 85%; the middle value sits exactly at the limit.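

The step from compound 2 to compound 4 cannot be read, because both compounds rest at the same limit, not at a number: the limit of > 64000 nM in this assay, at which 3 of the 4 values shown sit. The compounds shown leave open what replacing this chloro group with hydrogen does in this assay.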